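Swapping methoxy groups for fluorines on thin data

A few compounds are considered here, and "the series" means these few. Any claim that something is new, unique, unknown or untested is made for them only; others in the source may bear on it.

Compound 3 `COc1cc(CNc2ncnc3c2ncn3[C@@H]2O[C@H](CO)[C@@H](O)[C@H]2O)cc(OC)c1` has no number to stand on: in a functional assay on B16 cells (Mus musculus) for antiproliferative activity, with a stated time of 72 h (on this read-out lower numbers stand for stronger inhibition and higher numbers for weaker inhibition), compound 3 carries the entry "not determined" (no result reported) and nothing more. Compound 2 `COc1ccc(CNc2ncnc3c2ncn3[C@@H]2O[C@H](CO)[C@@H](O)[C@H]2O)c(OC)c1` likewise shows "not determined" (no result reported) as its entry. Next comes compound 4 `OC[C@H]1O[C@@H](n2cnc3c(NCc4ccc(F)cc4F)ncnc32)[C@H](O)[C@@H]1O` which is still unmeasured. The change 2,4-difluorophenyl in place of 3,5-dimethoxyphenyl on a saturated chain carbon bound to a nitrogen on an aromatic ring puts 2,4-difluorophenyl in place of 3,5-dimethoxyphenyl on a saturated chain carbon bound to a nitrogen on an aromatic ring. Compound 1 `OC[C@H]1O[C@@H](n2cnc3c(NCc4ccc(Cl)cc4)ncnc32)[C@H](O)[C@@H]1O` gives > 166000 nM as a limit and not a number. For the measured compounds named here, with that as the only guide, no step beyond the usual scatter is expected from compound 1 in this assay in either direction. Compound 4 is expected near 170000 nM with 50000 nM to 350000 nM as the likely range.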

Compound 4, half-maximal inhibitory concentration: > 166000 nM
Compound 4 ended at the assay's limit; the forecaster's own chance of this, stated with the estimate: 70%; the middle value lies beyond the limit too.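

Compound 1 and compound 4 each end at a limit and not at a number, so no step can be read between them: the limit of > 166000 nM in this assay, at which 2 of the 4 values shown sit.

The compounds shown leave open whether any group in this place gives a single number in this assay.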